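From Nitro to Acetyl: Expected Tolerance in Cells

The source may report more compounds than this note shows. Statements on the series, on what has been measured and on what is new or still open speak of the compounds shown alone.

Of the compounds shown here, three have so far been measured in an ADME assay on BHK cells (Mesocricetus auratus) for cytotoxicity, read by MTT assay, with a stated time of 96 h; a lower number here means that less compound is tolerated, a higher number that more compound is tolerated. Compound 1 `COc1ccc(-c2nc3cc(C(C)=O)ccc3[nH]2)c(OC)c1OC` gives > 100000 nM, which is a limit of the assay rather than a number. Compound 2 `COc1ccc(-c2nc3cc([N+](=O)[O-])ccc3[nH]2)c(OC)c1` gives > 100000 nM in this assay, again a limit. Compound 3 `CC(=O)Nc1ccc(-c2nc3cc([N+](=O)[O-])ccc3[nH]2)cc1` gives > 100000 nM in this assay, also a limit. For the measured compounds named here, all three rest at the limit of > 100000 nM in this assay, at which 3 of the 3 values shown sit, so compound 2 stands exactly where every measured compound stands: no number, only the limit, and no step between measured compounds can be counted.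

Compound 4 `COc1ccc(-c2nc3cc(C(C)=O)ccc3[nH]2)c(OC)c1` is not yet measured in this assay. It differs from compound 2 by acetyl in place of nitro on an aromatic carbon. Going by the values given here, with nothing but limits to draw on, no measured pair tells how large a step this change brings; the expectation is that the step from compound 2 to compound 4 in this assay stays within the scatter, estimated as a number no higher from compound 2 to compound 4 (the limit leaves the size open). Compound 4 is therefore expected to give 100000 nM in this assay, with an estimated range from 50000 nM to 300000 nM.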

Compound 4, half-maximal cytotoxic concentration: > 100000 nM
Compound 4 ended at the assay's limit; the forecaster's own chance of this, stated with the estimate: 85%; the middle value sits exactly at the limit.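

Neither the step from compound 2 to compound 4 nor the step from compound 1 to compound 4 can be read in this assay, because the values rest at one limit: the limit of > 100000 nM in this assay, at which 4 of the 4 values shown sit.

The compounds shown leave open what concentration of any of them the cells would fail to tolerate, and whether acetyl and nitro differ at all.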